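The source may report more compounds than this note shows. Statements on the series, on what has been measured and on what is new or still open speak of the compounds shown alone.

Of the compounds shown here, two so far have numbers in an in vivo ADME assay on the whole organism (strain 129/SvEvBrd x C57BL/6) for pharmacokinetics, with Mus musculus as the target; a lower number here means that a smaller share of the oral dose reaches the circulation, a higher number that a larger share of the oral dose reaches the circulation. Compound 1 (`OC[C@@H](O)[C@@H](O)[C@H](O)c1c[nH]c(C(F)(F)C(F)(F)F)n1`) gives 31% and compound 2 (`CC(=O)c1nc([C@@H](O)[C@@H](O)[C@H](O)CO)c[nH]1`) gives 25%. Among the compounds with values here, these two values lie within the scatter of each other, so compound 2 stands level with the only other measured compound. Compound 3 (`CC(=O)c1nc([C@H](O)[C@@H](O)[C@@H](O)CO)c[nH]1`) is next. Its relation to compound 2 is the two compounds have the same atoms and bonds and differ only in configuration as drawn: 2 of 3 stereo elements differ; a stereocentre at a saturated chain carbon is drawn R in compound 2 and S in compound 3; a stereocentre at a saturated chain carbon is drawn R in compound 2 and S in compound 3: two stereocentres at saturated chain carbons are drawn R in compound 2 and S in compound 3. Within the data shown here, no measured pair differs only in configuration, so the data give no direction for this change. No step beyond the scatter is therefore expected in this assay, in either direction, and compound 2 at 25% serves as the anchor. The expected no change at the digits printed from compound 2 to compound 3 (within the scatter) stays within the scatter. For compound 3 the estimate is 25%, with an expected range from 12% to 38%.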

Compound 3, oral bioavailability: 17%
The estimate for compound 3 lay 8 percentage points above the measured number; measured number inside the range.
By their numbers in this assay, from the lowest: compounds 3, 2 and 1 (each within the scatter of the next, the first and the last beyond it).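

Within the data shown here, this is the first pair that isolates configuration at the saturated chain carbons, and in this assay the step is a number 8 percentage points lower from compound 2 to compound 3 (within the scatter) for two of the three stereocentres inverted together. Changing these two centres as drawn therefore gives no step beyond the scatter, although a single pair cannot exclude a smaller effect. Only one structural source exists for any real gap between the two values: the fact that compounds 2 and 3 differ only in the configuration as drawn.

Among these compounds, the two inversions can be read only together, so the contribution of each centre stays unresolved, and the third stereocentre has no pair of its own. Also open, from the compounds shown here alone, is how the read-out responds to a single change of the acetyl group on the shared core, for instance to a carboxylic acid or an amine, with the chain left as it is.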